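The compounds below may be only part of what the source reports. "The series", "measured", "known", "first", "only" and "open" are said of these compounds alone.

Measured so far:

compound 1, `Oc1cc(C(F)(F)F)ccc1-c1nc(-c2ccccc2O)n(-c2ccc(F)cc2)n1`: 86.7%
compound 2, `Oc1cc(C(F)(F)F)ccc1-c1nc(-c2ccccc2O)n(-c2ccc(Br)cc2)n1`: 89.8%
compound 3, `COc1cccc(-n2nc(-c3ccc(C(F)(F)F)cc3O)nc2-c2ccccc2O)c1`: 96.8%

These three compounds share one core and differ only in the group carried on an aromatic nitrogen of that core. In a functional assay on PC-12 cells (Rattus norvegicus) for cytotoxicity, read by MTT assay, with stated times of 2 h and 24 h, tested at 5 uM (on this read-out higher numbers stand for a stronger effect at the one concentration tested and lower numbers for a weaker effect), compound 1 gives 86.7%, and it stands at the low end of the three numbers: compound 2 is a number 3.1 percentage points higher from compound 1 to compound 2 (within the scatter), while compound 3 is a number 10.1 percentage points higher from compound 1 to compound 3 (beyond the scatter), a modest gain.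

Compound 4, `Oc1cc(C(F)(F)F)ccc1-c1nc(-c2ccccc2O)n(-c2ccc(Cl)cc2Cl)n1`, has not yet been tested. It differs from compound 1 by 2,4-dichlorophenyl in place of 4-fluorophenyl on an aromatic nitrogen.

The step that bears most directly on this change is the one in which one halogen replaces another on the same ring, from compound 1 to compound 2: a number 3.1 percentage points higher from compound 1 to compound 2 (within the scatter), which stays within the scatter. The larger gain seen from compound 1 to compound 3 came with a different kind of group, a 3-methoxyphenyl, and so says less about compound 4. Within the data shown here, since the only halogen swap gave a number 3.1 percentage points higher from compound 1 to compound 2 (within the scatter), no step beyond the scatter is expected from compound 1 to compound 4 in this assay; the expected step is a number 2.3 percentage points higher from compound 1 to compound 4 (within the scatter). Compound 4 is therefore estimated to give 89%, in a range from 78% to 98%.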

Compound 4, a percentage reported as activity, at one concentration (the size of the read-out at that concentration, not a potency): 86.7%
The estimate for compound 4 lay 2.3 percentage points above the measured number; low and high end bracket the measured number.
By their numbers in this assay, from the lowest: compounds 1, 4, 2 and 3 (each within the scatter of the next, the first and the last beyond it).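

Placing 2,4-dichlorophenyl on the aromatic nitrogen instead of 4-fluorophenyl gives no change at the digits printed from compound 1 to compound 4 (within the scatter), and setting it against 4-bromophenyl gives a number 3.1 percentage points lower from compound 2 to compound 4 (within the scatter), so in this assay these three halogen-bearing groups cannot be told apart, even though the new group carries two chlorine atoms rather than a single halogen. Against 3-methoxyphenyl, the same group gives a number 10.1 percentage points lower from compound 3 to compound 4 (beyond the scatter), which means that 3-methoxyphenyl now stands clear of two halogen-bearing groups, those of compound 1 and compound 4, but still not of the 4-bromophenyl group of compound 2. Nothing measured here accounts for these numbers.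

All four groups at this position are substituted phenyl rings, so the compounds shown leave open what a phenyl ring carrying an amine or a carboxylic acid, or a plain alkyl chain in place of the ring, would give. Among these compounds, methoxy also appears only once, so a 4-methoxyphenyl group would be needed to show whether the number for compound 3 goes with the methoxy group itself or with its place on the ring.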